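Thiosemicarbazone series: swapping 2-chlorophenyl for ethyl

The source may hold more compounds than are shown below. What is called first, only, known or untested is meant among the compounds shown, and "the series" means these compounds.

Measured so far:
compound 1 `Fc1cccc(F)c1NC(=S)N/N=C\c1c[nH]c2ccccc12` — > 100000 nM
compound 2 `S=C(NCc1ccccc1Cl)N/N=C\c1c[nH]c2ccccc12` — > 100000 nM

Both compounds share a core and differ only in the group attached to the thiourea nitrogen. In an ADME assay on KB cells (Homo sapiens) for cytotoxicity, read by MTT assay, with a stated time of 44 h (a higher number here means a weaker inhibitor, a lower number a stronger inhibitor), compound 1 reaches only the limit of the assay, at > 100000 nM, which is a limit and not a number. In this assay compound 2 likewise reaches only a limit, at > 100000 nM. Going by the values given here, compound 2 therefore stands at the limit of > 100000 nM in this assay, at which 2 of the 2 values shown sit, and nothing measured so far separates it from compound 1.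

Compound 3 `CCCNC(=S)N/N=C\c1c[nH]c2ccccc12` has not yet been tested. It differs from compound 2 by ethyl in place of 2-chlorophenyl on a saturated chain carbon bound to an amide-type nitrogen. Among the compounds with values here, with no measured step in this set to lean on, there is no basis for expecting a change beyond the scatter in either direction. Compound 3 is expected to give 150000 nM in this assay, within 50000 nM to 500000 nM, most likely reported as a limit again. The step expected from compound 2 to compound 3 is a step that the limit leaves unreadable from compound 2 to compound 3, which is essentially no change.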

Compound 3, half-maximal inhibitory concentration: > 100000 nM
Compound 3 gave a limit, no number; the forecaster's own chance of this, stated with the estimate: 80%; the middle value lies beyond the limit too.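

In this assay compound 2 and compound 3 both give only a limit and not a number, so no step between them can be read: the limit of > 100000 nM in this assay, at which 3 of the 3 values shown sit.

Going by these compounds, what stays open is how far each compound lies past that limit, and whether any change to the shared core would give a readable number in this assay at all.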